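Swapping chloro for nitro on a potent compound

A few compounds are considered here, and "the series" means these few. Any claim that something is new, unique, unknown or untested is made for them only; others in the source may bear on it.

Going by the values given here, in a functional assay on CCRF-CEM cells (Homo sapiens) for antiproliferative activity, read by cell counting, with a stated time of 2 days (on this read-out higher numbers stand for weaker inhibition and lower numbers for stronger inhibition), compound 1 (`COc1ccc(Nc2nc(N)c(C(=O)c3ccc(Cl)cc3)s2)cc1`) gives 19 nM, the lower of the two numbers measured so far. Among the compounds with values here, the only comparison, compound 2 (`COc1ccccc1C(=O)c1sc(Nc2ccccc2)nc1N`), gives 730 nM. That gap lies beyond the usual scatter, but the two compounds differ in more than one place, so it isolates no single change. Compound 3 (`COc1ccc(Nc2nc(N)c(C(=O)c3ccc([N+](=O)[O-])cc3)s2)cc1`) keeps the core of compound 1 and carries nitro in place of chloro on an aromatic carbon, para to a large group (nitro in place of chloro on an aromatic carbon). Within the data shown here, no measured pair shows this swap, so any expectation here is loose. Compound 1 already sits at 19 nM, so a higher number seems likelier than a lower one. The expected change is moderate, a 3.7-fold higher number from compound 1 to compound 3 (0.57 log units; beyond the scatter), toward weaker inhibition. For compound 3, the estimated value is 70 nM, with an expected range from 15 nM to 350 nM.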

Compound 3, half-maximal inhibitory concentration: 31 nM
For compound 3 the middle estimate is 2.3-fold (0.35 log units) above the measured one; the range from low to high includes it.
By their numbers in this assay, from the lowest: compounds 1 and 3 (each within the scatter of the next); then compound 2.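

In this assay, putting nitro in place of chloro on an aromatic carbon, para to a large group, gives a 1.6-fold higher number from compound 1 to compound 3 (0.21 log units; within the scatter), so compound 1 and compound 3 cannot be told apart on this read-out. Going by these compounds alone, this is the first direct look at this position, and it shows that the low-nanomolar activity of compound 1 does not depend on chloro specifically: it also appears with nitro, which has three heavy atoms rather than one and brings two hydrogen-bond acceptors. No supporting measurement is available to explain why the two groups give such similar numbers.

With only these two groups compared here, the result cannot be extended to others. An amine or a carboxylic acid at this same place could give a very different number, and the compounds shown do not settle that.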